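The compounds below may be only part of what the source reports. "The series", "measured", "known", "first", "only" and "open" are said of these compounds alone.

In a functional assay on A549 cells (Homo sapiens) for antiproliferative activity, read by MTT assay, with a stated time of 48 h (on this read-out higher numbers stand for weaker inhibition and lower numbers for stronger inhibition), compound 1 (`O=C(/C=C/c1cc(Cl)cc(Cl)c1Oc1c([N+](=O)[O-])cc(C(F)(F)F)cc1[N+](=O)[O-])c1ccc(Cl)cc1`) gives 17.2 ug/mL and compound 2 (`O=C(/C=C/c1cccc(Br)c1Oc1c([N+](=O)[O-])cc(C(F)(F)F)cc1[N+](=O)[O-])c1ccc(Cl)cc1`) gives 16.5 ug/mL and so stands level with compound 1 within the scatter. Compound 3 (`O=C(/C=C/c1cccc(Cl)c1Oc1c([N+](=O)[O-])cc(C(F)(F)F)cc1[N+](=O)[O-])c1ccc(Cl)cc1`) carries chloro in place of bromo on an aromatic carbon. Within the data shown here, no measured step yet shows what this swap does, so no shift beyond the scatter is expected in this assay for this change. The expected step (a 1.0-fold higher number from compound 2 to compound 3 (0.01 log units; within the scatter)) stays within the scatter. Compound 3 is estimated at 17 ug/mL with a range of 9 ug/mL to 30 ug/mL expected.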

Compound 3, half-maximal inhibitory concentration: 11.7 ug/mL
Compound 3: middle estimate off by 1.5-fold (0.16 log units), on the high side, within the range that was stated.
By their numbers in this assay, from the lowest: compounds 3, 2 and 1 (each within the scatter of the next).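

Chloro in place of bromo on this aromatic carbon is the first swap at this position with a measured step, and in this assay it gives a 1.4-fold lower number from compound 2 to compound 3 (0.15 log units; within the scatter) for this pair of halogens. Hydrogen in place of chloro on an aromatic carbon gives a 1.5-fold lower number from compound 1 to compound 3 (0.17 log units; within the scatter) in the same assay, so neither single change moves the number beyond the scatter. Nothing at hand explains either step. Going by these compounds, whether an amine, a carboxylic acid or a methoxy group at this position would shift the number beyond the scatter remains open.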